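The source may hold more compounds than are shown below. What is called first, only, known or untested is meant among the compounds shown, and "the series" means these compounds.

Among the compounds with values here, compound 2 `CN1CCN(c2ncc3c(n2)CCN(C(=O)c2cc(Cc4n[nH]c(=O)c5ccccc45)ccc2F)C3)CC1` is the one member of this small set with a measured number. In a functional assay on HCC1937 cells (Homo sapiens) for inhibition, read by MTT assay, with a stated time of 48 h (a higher number here means a weaker inhibitor, a lower number a stronger inhibitor), compound 2 gives 53400 nM, which places it as a weak inhibitor. Compound 1 `O=C(c1cc(Cc2n[nH]c(=O)c3ccccc23)ccc1F)N1CCc2nc(Cl)ncc2C1` shares the same core, but in this assay compound 1 shows only "nd" (no result reported), no result recorded, so compound 2 stands alone among the numbers shown. The step to compound 3 `CCCCN(CCCC)c1ncc2c(n1)CCN(C(=O)c1cc(Cc3n[nH]c(=O)c4ccccc34)ccc1F)C2` changes one place on the core: dibutylamino in place of 4-methylpiperazin-1-yl on an aromatic carbon. Within the data shown here, no measured pair in this set reports a step of this kind, so there is nothing to calibrate the size or direction of the change, and the expectation rests only on the single value of compound 2. Compound 3 is therefore expected to stay close to compound 2, with a step of a 1.2-fold lower number from compound 2 to compound 3 (0.07 log units; within the scatter) that lies within the usual scatter. The estimated potency of compound 3 in this assay is 45000 nM, within a range from 15000 nM to 150000 nM.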

Compound 3, half-maximal inhibitory concentration: > 200000 nM
Compound 3 ended at the assay's limit (the forecaster's own chance of this, stated with the estimate: 25%); middle value at least 4.4-fold (0.64 log units) from the limit.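

Within the data shown here, on this aromatic carbon, between two ring nitrogen atoms, the exchange of 4-methylpiperazin-1-yl for dibutylamino gives the first readable step in the set, an at least 3.7-fold higher number from compound 2 to compound 3 (0.57 log units; beyond the scatter). It shows that the group at this position can shift the result in this assay beyond the scatter, and that here the ring-free dibutylamino goes with the higher number. Compound 3 sits at a limit of the assay, so its step fixes a direction and only a minimum size: the limit of > 200000 nM in this assay, at which 1 of the 3 values shown sits.

The compounds shown leave open whether a ring amine such as piperidine or morpholine, or a shorter chain such as dimethylamino, would read closer to compound 2 or to compound 3. They also leave open whether any group at this carbon would give a number lower than that of compound 2.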